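A Methyl Group Added to Compound 2

The source may hold more compounds than are shown below. What is called first, only, known or untested is meant among the compounds shown, and "the series" means these compounds.

In a functional assay on MCF7 cells (Homo sapiens) for inhibition, with a stated time of 48 h (on this read-out lower numbers stand for stronger inhibition and higher numbers for weaker inhibition), compound 1 `COc1cc(Sc2c(C)[nH]c3ccc(Cl)cc23)cc(OC)c1OC` gives 82 nM, while compound 2 `COc1ccc2[nH]cc(Sc3cc(OC)c(OC)c(OC)c3)c2c1` gives 22 nM, the lower of the two numbers and a gap beyond the scatter. Compound 3 `COc1ccc2[nH]c(C)c(Sc3cc(OC)c(OC)c(OC)c3)c2c1` differs from compound 2 by methyl in place of hydrogen on an aromatic carbon, with methyl in place of hydrogen on an aromatic carbon, next to the ring nitrogen. Among the compounds with values here, no measured pair isolates this change. Compound 1 also carries a methyl there and gives 82 nM, so a modest rise in the number is expected. The estimated change is a 1.6-fold higher number from compound 2 to compound 3 (0.20 log units; within the scatter), possibly within the scatter. For compound 3 the expected value is 35 nM, with an estimated range of 11 nM to 110 nM.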

Compound 3, half-maximal inhibitory concentration: 18 nM
Compound 3: middle estimate off by 1.9-fold (0.29 log units), on the high side; the measured number falls inside the stated range.
By their numbers in this assay, from the lowest: compounds 3 and 2 (each within the scatter of the next); then compound 1.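

In this assay methyl in place of hydrogen on an aromatic carbon, next to the ring nitrogen, gives a 1.2-fold lower number from compound 2 to compound 3 (0.09 log units; within the scatter) and so leaves the number unchanged within the scatter. With methyl present in both compounds, methoxy in place of chloro gives a 4.6-fold lower number from compound 1 to compound 3 (0.66 log units; beyond the scatter) and this gap lies beyond the scatter. The higher number of compound 1 therefore goes with its chloro group, not with the methyl. From the compounds shown here alone, whether an ethyl group or an amine would be accepted at this position remains open. Nothing available explains either step.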